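This account rests on a few compounds, and the source may have more. Where it says the series, first, only, none or still open, it means among the compounds named here.

Measured compounds:
compound 1, `COC(=O)/C=C/c1cccc(N(Cc2ccc(-c3ccc(F)c(Cl)c3)cc2)C(=O)C2CCCCC2)c1` – 66 nM
compound 2, `COC(=O)/C=C/c1cccc(N(Cc2ccc(/C=C/C(=O)OCc3ccccc3)cc2)C(=O)C2CCCCC2)c1` – > 1000 nM

In an assay on isolated protein with Bile acid receptor (Homo sapiens) as the target (a higher number here means that more compound is needed for the effect, a lower number that less compound is needed), compound 1 gives 66 nM. Compound 2 gives > 1000 nM, which is a limit of the assay and not a number. Compound 2 therefore stands at the limit of > 1000 nM in this assay, at which 1 of the 2 values shown sits; its true value could lie anywhere beyond that limit.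

Within the data shown here, the only measured step is an at least 15-fold higher number from compound 1 to compound 2 (1.18 log units; beyond the scatter). That step swapped a chlorinated, fluorinated aromatic ring for a chain ending in an ester and cost a large amount of potency.

Compound 3, `COC(=O)/C=C/c1cccc(N(Cc2ccc(/C=C/c3cccc(Cl)c3)cc2)C(=O)C2CCCCC2)c1`, has not been measured. It differs from compound 2 in one place: 3-chlorophenyl in place of benzyloxycarbonyl on a double-bonded chain carbon bound to a double-bonded chain carbon. The ester part that entered in the step from compound 1 to compound 2 leaves again, and a chlorinated aromatic ring comes back, now held on the double-bonded chain rather than directly on the ring. The measured step thus bears on this change, and a move in the opposite direction, towards a lower number, is expected, though compound 1 and compound 3 are not the same, so a smaller recovery is expected than the full loss seen. The expected step is an at least 3.3-fold lower number from compound 2 to compound 3 (0.52 log units; beyond the scatter). Compound 3 is estimated at 300 nM, with a range from 60 nM to 1500 nM.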

Compound 3, half-maximal effective concentration: 165 nM
The estimate for compound 3 lay 1.8-fold (0.26 log units) above the measured number; the range from low to high includes it.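

Putting 3-chlorophenyl in place of benzyloxycarbonyl on the double-bonded chain brings an at least 6.0-fold lower number from compound 2 to compound 3 (0.78 log units; beyond the scatter) in this assay, so the double-bonded chain does not by itself cost all of the potency, and much of the loss seen in compound 2 goes with its benzyloxycarbonyl end. From the compounds shown here alone, the true size of this step stays open on one side, since compound 2 stands at a limit of the assay and not at a number: the limit of > 1000 nM in this assay, at which 1 of the 3 values shown sits. The recovery is only partial, as 2-(3-chlorophenyl)ethenyl in place of 3-chloro-4-fluorophenyl leaves a 2.5-fold higher number from compound 1 to compound 3 (0.40 log units; beyond the scatter), so an aromatic ring held on the chain comes close to the ring bound directly in compound 1 but does not match it.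

Compound 3 differs from compound 1 both in having the double-bonded chain and in lacking the fluorine, and the compounds shown cannot separate these two changes. They also leave open how the double-bonded chain would fare if its 3-chlorophenyl ring carried an amine or a carboxylic acid in place of the chlorine.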